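The compounds below may be only part of what the source reports. "The series", "measured", "known", "first", "only" and "open" are said of these compounds alone.

Measured so far in a functional assay on the whole organism with Mus musculus as the target; on this read-out lower numbers stand for an effect already at smaller amounts and higher numbers for an effect only at larger amounts of compound
compound 1 `CCN(CC)C(=O)Cn1c(-c2ccc(Cl)cc2)nc2cccnc21` gives 16 mg/kg
compound 2 `CCCN(CCC)C(=O)Cn1c(-c2ccc(Cl)cc2)nc2cccnc21` gives 11 mg/kg
compound 3 `O=C(Cn1c(-c2ccc(Cl)cc2)nc2cccnc21)Nc1cccnc1` gives 100 mg/kg

Compound 3 has the highest number of the three. The steps of a 6.3-fold higher number from compound 1 to compound 3 (0.80 log units; beyond the scatter) and a 9.1-fold higher number from compound 2 to compound 3 (0.96 log units; beyond the scatter) both lie beyond the scatter, while a 1.5-fold lower number from compound 1 to compound 2 (0.16 log units; within the scatter) stays within it.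

Next is compound 4 `CCOC(=O)CCCNC(=O)Cn1c(-c2ccc(Cl)cc2)nc2cccnc21` with the change 3-(ethoxycarbonyl)propyl in place of pyridin-3-yl on an amide-type nitrogen on the amide: 3-(ethoxycarbonyl)propyl in place of pyridin-3-yl on an amide-type nitrogen. For the measured compounds named here, no measured step makes this exact change. The closest evidence is a 6.3-fold higher number from compound 1 to compound 3 (0.80 log units; beyond the scatter) read in reverse, and a 9.1-fold higher number from compound 2 to compound 3 (0.96 log units; beyond the scatter) read the same way, as both involve loss or gain of the pyridin-3-yl ring. The nitrogen of compound 4 keeps its hydrogen, unlike that of compound 1 and compound 2, so only part of that gap is expected to return.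

In this assay the estimated step is a 2.5-fold lower number from compound 3 to compound 4 (0.40 log units; beyond the scatter) and it is expected to be modest. For compound 4 the estimate is 40 mg/kg with an expected range from 14 mg/kg to 110 mg/kg in this measurement.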

Compound 4, dose for half-maximal effect: 100 mg/kg
The estimate for compound 4 lay 2.5-fold (0.40 log units) below the measured number; the range from low to high includes it.
By their numbers in this assay, from the lowest: compounds 2 and 1 (each within the scatter of the next); then compounds 3 and 4 (each within the scatter of the next).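

In this assay the exchange of pyridin-3-yl for 3-(ethoxycarbonyl)propyl on the amide-type nitrogen gives no change at the digits printed from compound 3 to compound 4 (within the scatter) and so shows that this position accepts loss of the ring without any separation in the read-out. With the open chain in place there is still a 9.1-fold higher number from compound 2 to compound 4 (0.96 log units; beyond the scatter) and a 6.3-fold higher number from compound 1 to compound 4 (0.80 log units; beyond the scatter) in the same assay, so the gap between the two compounds with the amide hydrogen and the two dialkylamides does not depend on the pyridin-3-yl ring. Nothing at hand accounts for this gap.

Going by these compounds, whether the gap follows the amide hydrogen itself or merely these two substituents remains open. A plain propyl on this nitrogen, or the free carboxylic acid in place of the ethyl ester, would help separate these readings.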